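The source may hold more compounds than are shown below. What is called first, only, known or untested is meant among the compounds shown, and "the series" means these compounds.

Of the compounds shown here, three have been measured in a functional assay on P388 cells (Mus musculus) for cytotoxicity, read by MTT assay, with a stated time of 72 h; on this read-out higher numbers stand for weaker inhibition and lower numbers for stronger inhibition. Compound 1 `CSc1c(SCC#CCO)cnc2ccccc12` gives 32.3 ug/mL in this assay. Compound 2 `C#CCSc1c(SCC#CCO)cnc2ccccc12` gives 13.3 ug/mL, and compound 3 `C#CCSc1cnc2ccccc2c1[Se]CC#CCO` gives 3.1 ug/mL, the lowest of the three numbers, with both other compounds standing beyond the scatter of it. Compound 1 differs from compound 2 in one place: hydrogen in place of ethynyl on a saturated chain carbon bound to a sulfur. That single change made the step of a 2.4-fold higher number from compound 2 to compound 1 (0.39 log units; beyond the scatter). How compound 2 and compound 3 differ in their cores is not broken down here; their values alone show compound 3 at the stronger end of the three.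

Compound 4 `CSc1cnc2ccccc2c1[Se]CC#CCO` has not yet been measured in this assay. It differs from compound 3 by the same change: hydrogen in place of ethynyl on a saturated chain carbon bound to a sulfur. The change therefore occurs twice among these compounds, once measured and once awaiting measurement, and in both cases it sits on a saturated chain carbon bound to a sulfur, so it is the same change in the same place. The step expected here is a 2.4-fold higher number from compound 3 to compound 4 (0.38 log units; beyond the scatter). That expectation rests on the measured step of a 2.4-fold higher number from compound 2 to compound 1 (0.39 log units; beyond the scatter) being carried over, with no reason visible in these data for it to change direction or size. Compound 4 is accordingly expected to give about 7.4 ug/mL in this assay. The estimated range for compound 4 runs from 3.5 ug/mL to 16 ug/mL.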

Compound 4, concentration for 50% inhibition: 2.6 ug/mL
Estimate against measurement, compound 4: 2.8-fold (0.45 log units) above; the measured number lies below the stated range.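

In this assay, the exchange of propargylsulfanyl for methylsulfanyl did not carry over unchanged from one core to the other: on the core of compound 3 it gave a 1.2-fold lower number from compound 3 to compound 4 (0.08 log units; within the scatter), so compound 3 and compound 4 cannot be told apart on this read-out. Set beside the step on the other core, this one differs by more than repeated measurements would explain: the same change on two cores in this assay, a 2.4-fold higher number (0.39 log units; beyond the scatter) from compound 2 to compound 1 and a 1.2-fold lower number (0.08 log units; within the scatter) from compound 3 to compound 4, 2.9-fold (0.46 log units) apart, beyond the scatter of two such steps Within these four compounds, the effect of this change therefore depends on the core that carries it, but two pairs do not show which feature of the cores matters, nor how the change would behave on any further core.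

The compounds shown carry only propargyl or methyl on this sulfur, so it remains open how an ethyl group, a longer chain or an amine-bearing chain would read on either core. The hydroxyl-ended alkyne chain is also the same in all four compounds, which leaves open whether the difference between the two steps would persist with a carboxylic acid in place of that hydroxyl.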